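Notes on the step to compound 3

The source may report more compounds than this note shows. Statements on the series, on what has been measured and on what is new or still open speak of the compounds shown alone.

In a functional assay on HL-60 cells (Homo sapiens) for antiproliferative activity, read by MTT assay, with a stated time of 24 h (on this read-out higher numbers stand for weaker inhibition and lower numbers for stronger inhibition), the measured compounds read as follows.
- Compound 1 `CCCCc1oc2ccccc2c1C(=O)c1ccc(OCC(=O)N2CCCC2)cc1` gives > 50000 nM as a limit
- Compound 2 `CCCCc1oc2ccccc2c1C(=O)c1ccc(OCC(=O)NCc2ccccc2)cc1` gives > 50000 nM as a limit

Compound 2 stands only at a limit, and both compounds sit at the limit of > 50000 nM in this assay, at which 2 of the 2 values shown sit, with no number available. Among the measured compounds shown here, compound 3 `CCCCc1oc2ccccc2c1C(=O)c1ccc(OCCCC(=O)N2CCCC2)cc1` follows from compound 2 by 2-((pyrrolidin-1-yl)carbonyl)ethyl in place of benzylcarbamoyl on a saturated chain carbon bound to an oxygen on an aromatic ring as the sole change. For the measured compounds named here, the only measured step is a step that the two limits leave unreadable from compound 1 to compound 2 and it offers no size to carry over, so no size or direction can be firmly expected in this assay here. The expected step is a number no higher from compound 2 to compound 3 (the limit leaves the size open) and it rests on no readable size. For compound 3 the estimate is 50000 nM within an expected range of 20000 nM to 100000 nM and a further limit is likely.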

Compound 3, half-maximal inhibitory concentration: 29900 nM
Beside the measured number, compound 3's estimate is 1.7-fold (0.22 log units) above it; the measured number falls inside the stated range.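

In this assay, among the compounds shown here, compound 3 is the first of the series to give a number and not a limit: the limit of > 50000 nM in this assay, at which 2 of the 3 values shown sit. With 2-((pyrrolidin-1-yl)carbonyl)ethyl on the saturated chain carbon bound to an oxygen on an aromatic ring, the reading is an at least 1.6-fold lower number from compound 2 to compound 3 (0.22 log units; that floor lies within the scatter), and an at least 1.6-fold lower number from compound 1 to compound 3 (0.22 log units; that floor lies within the scatter). Both steps are floors only, so this change shows no firm gain in this assay.

As far as these compounds go, the true size of either step stays open. Also open, from the compounds shown here alone, is how a longer chain, or a carboxylic acid in place of the pyrrolidine amide, would read at this place.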